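Hydroxy for methylsulfanyl on the aryl ether of compound 2

This account rests on a few compounds, and the source may have more. Where it says the series, first, only, none or still open, it means among the compounds named here.

For the measured compounds named here, compound 2 `CSc1ccccc1OC(C)(C)C1OCC(C/C=C\CCC(=O)O)C(c2cccnc2)O1` gives the lowest of the two numbers measured so far in an assay for inhibition of Thromboxane-A synthase (Homo sapiens), using microsomes (on this read-out lower numbers stand for stronger inhibition and higher numbers for weaker inhibition), 36 nM, with compound 1 `CC(C)(Oc1ccccc1F)C1OCC(C/C=C\CCC(=O)O)C(c2cccnc2)O1` nearest at 45 nM; the two lie within the scatter of each other, so no order between them can be claimed. Going by the values given here, the one measured step that bears on the present question is a 1.3-fold lower number from compound 1 to compound 2 (0.10 log units; within the scatter), which exchanged one substituent for another at the same aromatic carbon without moving the read-out beyond the scatter. Compound 3 `CC(C)(Oc1ccccc1O)C1OCC(C/C=C\CCC(=O)O)C(c2cccnc2)O1` carries the next exchange at that carbon: hydroxy in place of methylsulfanyl on an aromatic carbon. Among the compounds with values here, with only a single, scatter-sized step to lean on, and no hydroxy-bearing compound measured in this assay, the expectation is that compound 3 stays near compound 2, giving an estimated 1.3-fold higher number from compound 2 to compound 3 (0.10 log units; within the scatter). Compound 3 is therefore expected at about 45 nM, with a likely range from 15 nM to 150 nM.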

Compound 3, half-maximal inhibitory concentration: 32 nM
The estimate for compound 3 lay 1.4-fold (0.15 log units) above the measured number, within the range that was stated.
By their numbers in this assay, from the lowest: compounds 3, 2 and 1 (each within the scatter of the next).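

In this assay, this aromatic carbon, ortho to a large group, now carries a third substituent with the read-out still inside the scatter, both for hydroxy against methylsulfanyl (a 1.1-fold lower number from compound 2 to compound 3 (0.05 log units; within the scatter)) and for hydroxy against fluoro (a 1.4-fold lower number from compound 1 to compound 3 (0.15 log units; within the scatter)). The step from compound 2 to compound 3 swaps a group of 2 heavy atoms with 0 hydrogen-bond donors for one of 1 heavy atom with 1 hydrogen-bond donor, and these differences in count do not separate the two compounds on this read-out. Nothing measured here speaks to why the three compounds lie so close.

From the compounds shown here alone, whether an amine, a carboxylic acid or a longer chain such as butoxy at this carbon would also stay within the scatter remains open. The compounds shown also leave open whether the same holds for hydroxy placed on another carbon of this ring.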